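The source may hold more compounds than are shown below. What is called first, only, known or untested is meant among the compounds shown, and "the series" means these compounds.

In a functional assay on DU-145 cells (Homo sapiens) for cytotoxicity, read by trypan blue exclusion, with a stated time of 96 h (on this read-out lower numbers stand for stronger inhibition and higher numbers for weaker inhibition), compound 1 (`COc1ccc(CS(=O)(=O)/C=C/c2c(OC)cc(OC)cc2OC)c(N)c1`) gives 25 nM and compound 2 (`COc1ccc(CS(=O)(=O)/C=C/c2cc(OC)c(OC)cc2OC)cc1N`) gives 250 nM as the two lower numbers. Compound 3 (`COC(=O)[C@H](C)Nc1cc(CS(=O)(=O)/C=C/c2c(OC)cc(OC)cc2OC)ccc1OC`) stands at 750 nM as the highest of the three, beyond the scatter from both others. Compound 4 (`COc1cc(OC)c(/C=C/S(=O)(=O)Cc2ccc(OC)c(N[C@@H](C)C(=O)O)c2)c(OC)c1`) differs from compound 3 by hydrogen in place of methyl on an oxygen next to a carbonyl group, methoxycarbonyl to carboxy (hydrogen in place of methyl on an oxygen next to a carbonyl group). For the measured compounds named here, no measured pair shows this change, so the size of the step in this assay is a judgement: a moderate move to a lower number is expected, since compound 3 at 750 nM sits at the top of the measured range. The estimated move is a 2.5-fold lower number from compound 3 to compound 4 (0.40 log units; beyond the scatter) and remains uncertain. Compound 4 is expected at 300 nM within an estimated range of 50 nM to 2000 nM on this read-out.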

Compound 4, half-maximal inhibitory concentration: 25 nM
Beside the measured number, compound 4's estimate is 12-fold (1.08 log units) above it, outside the stated range (below it).
By their numbers in this assay, from the lowest: compounds 1 and 4 (each within the scatter of the next); then compound 2; then compound 3.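

Methoxycarbonyl to carboxy gives a 30-fold lower number from compound 3 to compound 4 (1.48 log units; beyond the scatter) in this assay and is the only step in the series that differs in one place. For the compounds shown here, this site, on an oxygen next to a carbonyl group, is therefore highly sensitive to hydrogen in place of methyl, which the earlier compounds, all differing in more than one place, could not show. No data here bear on the reason for a step of this size.

From the compounds shown here alone, it remains open whether a primary amide or an ethyl ester at this site would track compound 3 or compound 4. Also open, going by these compounds, is whether a longer chain carrying the carboxylic acid would preserve the step.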